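The source may report more compounds than this note shows. Statements on the series, on what has been measured and on what is new or still open speak of the compounds shown alone.

Among the measured compounds shown here, in an assay on membranes from brain for displacement of a labelled ligand from Neuronal acetylcholine receptor; alpha4/beta2 (Rattus norvegicus), with a stated time of 3 h (on this read-out lower numbers stand for stronger inhibition and higher numbers for weaker inhibition), compound 2 `COc1ccc(/C=C2\CCCN=C2c2cccnc2)c(OC)c1` gives 250 nM, the lower of the two numbers measured so far. For the measured compounds named here, compound 1 `COc1ccc(/C=C2\CCCN=C2c2cccnc2)c(OC(C)=O)c1` gives 770 nM, and the one measured step, a 3.1-fold lower number from compound 1 to compound 2 (0.49 log units; beyond the scatter), exchanged the group on the oxygen without removing it. Compound 3 `COc1ccc(/C=C2\CCCN=C2c2cccnc2)cc1` differs from compound 2 by hydrogen in place of methoxy on an aromatic carbon. Going by the values given here, no measured step shows what loss of the whole methoxy does, so for compound 3 the expected step in this assay is a 1.2-fold higher number from compound 2 to compound 3 (0.08 log units; within the scatter), not clearly beyond the scatter in either direction. Compound 3 is therefore estimated at about 300 nM in this assay, with a range from 80 nM to 1200 nM.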

Compound 3, inhibition constant: 490 nM
Estimate against measurement, compound 3: 1.6-fold (0.21 log units) below; measured number inside the range.
By their numbers in this assay, from the lowest: compounds 2, 3 and 1 (each within the scatter of the next, the first and the last beyond it).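

In this assay, hydrogen in place of the whole methoxy gives a 2.0-fold higher number from compound 2 to compound 3 (0.29 log units; within the scatter) and so does not show that this position needs a methoxy group. Hydrogen in place of acetoxy gives a 1.6-fold lower number from compound 1 to compound 3 (0.20 log units; within the scatter) as well, so compound 3 cannot be separated from either oxygen-bearing compound, although those two remain apart through a 3.1-fold lower number from compound 1 to compound 2 (0.49 log units; beyond the scatter) on the same position. No evidence is given that would explain these numbers. As far as these compounds go, whether an amine or a carboxylic acid on this carbon, or a longer chain on its oxygen, would shift the number beyond the scatter stays open.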